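Aryl ether to aryl thioether on the shared core

This account rests on a few compounds, and the source may have more. Where it says the series, first, only, none or still open, it means among the compounds named here.

Compound 1, `COc1ccc(Sc2nc3cc(N)cc(N)c3nc2-c2ccccc2)cc1`, gives < 100000 nM in a functional assay on OVCAR-3 cells (Homo sapiens) for inhibition, read by sulforhodamine B assay, with a stated time of 48 h (on this read-out higher numbers stand for lower toxicity in this test and lower numbers for higher toxicity in this test), which is a limit of the assay.
Compound 2, `Nc1cc(N)c2nc(-c3ccccc3)c(Oc3ccc(F)cc3)nc2c1`, gives < 100000 nM in this assay, also a limit.

Compound 2 thus stands only at a limit, and (the limit of < 100000 nM in this assay, at which 2 of the 2 values shown sit). Within the data shown here, the single measured step, a step that the two limits leave unreadable from compound 1 to compound 2, is unreadable; its change is 4-fluorophenoxy in place of (4-methoxyphenyl)sulfanyl on an aromatic carbon. Compound 3, `Nc1cc(N)c2nc(-c3ccccc3)c(Sc3ccc(F)cc3)nc2c1`, differs from compound 2 by (4-fluorophenyl)sulfanyl in place of 4-fluorophenoxy on an aromatic carbon. Among the measured compounds shown here, no measured step reads on this change, so no direction beyond the scatter is expected and a limit is the likely report in this assay. Compound 3 is expected at 50000 nM, with a range from 10000 nM to 100000 nM, meaning an expected step that the limit leaves unreadable from compound 2 to compound 3.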

Compound 3, concentration lethal to 50% of the cells: 69200 nM
Compound 3: the middle estimate sits 1.4-fold (0.14 log units) below what was measured; the range from low to high includes it.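

No step to compound 3 can be read from compound 1 or compound 2 in this assay, because both stand at a limit: the limit of < 100000 nM in this assay, at which 2 of the 3 values shown sit.

On these data alone, whether (4-fluorophenyl)sulfanyl in place of 4-fluorophenoxy shifts the value on the shared core stays open.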